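The source may hold more compounds than are shown below. What is called first, only, known or untested is meant among the compounds shown, and "the series" means these compounds.

Compound 3 `CCCCCCCCCCNC(=O)CCCSC[C@H](NC(=O)OCc1ccccc1)C(=O)Nc1ccccc1` gives 28% in an assay for inhibition of NAD-dependent protein deacylase sirtuin-6 (Homo sapiens), read by HPLC, with stated times of 15 min and 1 h, tested at 333 uM (a lower number here means less inhibition, a higher number more inhibition at the concentration tested (going by the name of the read-out)), the lowest of the two numbers reported here. Compound 1 `O=C(O)CCNC(=O)CCCSC[C@H](NC(=O)OCc1ccccc1)C(=O)Nc1ccccc1` gives 43% in this assay, and compound 2 `CCCCCCNC(=O)CCCSC[C@H](NC(=O)OCc1ccccc1)C(=O)Nc1ccccc1` is reported in this assay only as "not active" (no number reported), with no number attached. Going by the values given here, the one measured step that alters the same end of the molecule, a number 15 percentage points lower from compound 1 to compound 3 (beyond the scatter), shows a modest loss when a long chain takes the place of the carboxy group. Compound 4 `NC(=O)CCCSC[C@H](NC(=O)OCc1ccccc1)C(=O)Nc1ccccc1` differs from compound 3 by hydrogen in place of decyl on an amide-type nitrogen. Among the compounds with values here, no measured step strips the chain from the amide nitrogen entirely, so the data give no direct guide; compound 1 and compound 3 show that what sits on this nitrogen shifts the read-out modestly, while compound 2 shows a hexyl chain leaving no measurable inhibition. Compound 4 is therefore expected to change by about a number 3 percentage points lower from compound 3 to compound 4 (within the scatter), a step within the usual scatter. The estimate for compound 4 is 25%, with a range from 5% to 45%.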

Compound 4, a percentage reported as inhibition, at one concentration (the size of the read-out at that concentration, not a potency): 11%
Estimate against measurement, compound 4: 14 percentage points above; low and high end bracket the measured number.
By their numbers in this assay, from the lowest: compound 4; then compound 3; then compound 1.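

Putting hydrogen in place of decyl on this amide-type nitrogen lowers the read-out in this assay, with a number 17 percentage points lower from compound 3 to compound 4 (beyond the scatter), and putting hydrogen in place of 2-carboxyethyl lowers it further, with a number 32 percentage points lower from compound 1 to compound 4 (beyond the scatter). The earlier compounds shown here all carried a chain on this nitrogen, so only now is it visible that both decyl and 2-carboxyethyl give more inhibition than hydrogen alone, although compound 2, with its hexyl chain, goes against this pattern as "not active" (no number reported), and no step to it can be read. No measurement here accounts for these differences.

The compounds shown leave open how a chain ending in an amine would compare with the one ending in a carboxylic acid. A longer chain carrying a carboxylic acid also remains an open case.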